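Chain-end change on the limit-bound compound 2

This account rests on a few compounds, and the source may have more. Where it says the series, first, only, none or still open, it means among the compounds named here.

Measured in a functional assay on MDA-MB-231 cells (Homo sapiens) for inhibition, read by MTT assay, with a stated time of 72 h; on this read-out lower numbers stand for stronger inhibition and higher numbers for weaker inhibition:
- compound 1 `Nc1ncnc2c1c(-c1cnc3[nH]ccc3c1)nn2CC(=O)NO`: > 150000 nM
- compound 2 `Nc1nc2cc(-c3nn(CCCCCCCCCC(=O)NO)c4ncnc(N)c34)ccc2o1`: > 50000 nM
- compound 3 `Nc1ncnc2c1c(-c1cnc3[nH]ccc3c1)nn2CCCCCCCCCC(=O)NO`: 10100 nM

Not yet measured: compound 4 `CNC(=O)CCCCCCCn1nc(-c2ccc3oc(N)nc3c2)c2c(N)ncnc21`.

Compound 2 gives no number, only the limit > 50000 nM. The change is methylcarbamoyl in place of 2-(hydroxycarbamoyl)ethyl on a saturated chain carbon, seven bonds along the chain from an aromatic nitrogen. For the measured compounds named here, the one measured step, an at least 4.9-fold lower number from compound 2 to compound 3 (0.69 log units; beyond the scatter), swaps the aromatic group and leaves the chain end untouched, so it bears only indirectly. Going by the values given here, no measured step covers the chain-end change. Compound 4 keeps the aromatic group of compound 2, so no gain is expected in this assay. The expected step is a step that the limit leaves unreadable from compound 2 to compound 4, no clear move beyond the scatter. Compound 4 is estimated at 70000 nM, range 25000 nM to 200000 nM, and may well be reported only as a limit.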

Compound 4, half-maximal inhibitory concentration: 2900 nM
The estimate for compound 4 lay 24-fold (1.38 log units) above the measured number; measured number outside the range, below it.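

In this assay, the chain end proves to be a site of large change: methylcarbamoyl in place of 2-(hydroxycarbamoyl)ethyl gives an at least 17-fold lower number from compound 2 to compound 4 (1.23 log units; beyond the scatter). With the aromatic group of compound 2 kept, a measured value therefore does not require the hydroxycarbamoyl end. The step has a floor and no exact size because compound 2 stands only at a limit: the limit of > 50000 nM in this assay, at which 1 of the 4 values shown sits.

Open, from the compounds shown here alone, is whether methylcarbamoyl does the same with the aromatic group of compound 3. Also open, going by these compounds, is what a carboxylic acid, a primary amide or a longer chain would give at this position.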